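This account rests on a few compounds, and the source may have more. Where it says the series, first, only, none or still open, it means among the compounds named here.

Compound 1 `Cc1cc(C(=O)Nc2ccccn2)nn1Cc1cc(Cl)ccc1OCc1ccccc1`: 126 nM
Compound 2 `Cc1cc(NC(=O)C(C)C)nn1Cc1cc(Cl)ccc1OCc1ccccc1`: 25.1 nM

Among the compounds with values here, in an assay on CHO-K1 cells for displacement of a labelled ligand from prostaglandin E2 receptor EP1 subtype (Homo sapiens) (on this read-out higher numbers stand for weaker inhibition and lower numbers for stronger inhibition), compound 2 gives 25.1 nM, the lowest of the two numbers; the only other measured compound is compound 1 with 126 nM, and the one measured step, a 5.0-fold lower number from compound 1 to compound 2 (0.70 log units; beyond the scatter), concerns a different change. Compound 3 `Cc1cc(NC(=O)CC2CCCCC2)nn1Cc1cc(Cl)ccc1OCc1ccccc1` differs from compound 2 by cyclohexylmethyl in place of isopropyl on a carbonyl carbon. Within the data shown here, no measured step bears on this change, so no direction can be drawn from the data, and a step of a 1.2-fold higher number from compound 2 to compound 3 (0.08 log units; within the scatter) is expected only as an estimate. Compound 3 is therefore expected at 30 nM, with a range from 8 nM to 120 nM.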

Compound 3, half-maximal inhibitory concentration: 6.31 nM
Compound 3: the middle estimate sits 4.8-fold (0.68 log units) above what was measured, and the stated range ends above it.
By their numbers in this assay, from the lowest: compound 3; then compound 2; then compound 1.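

In this assay, the group on the carbonyl carbon clearly matters: cyclohexylmethyl in place of isopropyl, which adds a six-membered non-aromatic ring of carbon only, gives a stronger result (a 4.0-fold lower number from compound 2 to compound 3 (0.60 log units; beyond the scatter)). Against the (pyridin-2-yl)carbamoyl group, ((cyclohexylmethyl)carbonyl)amino gives the largest step so far (a 20-fold lower number from compound 1 to compound 3 (1.30 log units; beyond the scatter)). Nothing available explains why this change helps.

The compounds shown leave open whether the ring itself matters or only the added carbons, as a straight hexyl chain in the same place could tell. As far as these compounds go, whether a benzyl group would serve as well also stays open.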